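The source may hold more compounds than are shown below. What is called first, only, known or untested is meant among the compounds shown, and "the series" means these compounds.

Measured so far in an ADME assay on HEp-2 cells (Homo sapiens) for cytotoxicity; a lower number here means that less compound is tolerated, a higher number that more compound is tolerated:
compound 1 `CC(C)S(=O)(=O)CCCn1c(Cn2c(=O)n(C3CC3)c3ccncc32)nc2ccccc21` gives 49200 nM.
compound 2 `O=c1n(Cc2nc3ccccc3n2CCCCCO)c2cnccc2n1C1CC1` gives only a limit, > 229000 nM.

Compound 2 thus stands at the limit of this assay (the limit of > 229000 nM in this assay, at which 1 of the 2 values shown sits), and the step of an at least 4.6-fold higher number from compound 1 to compound 2 (0.66 log units; beyond the scatter) reaches only that limit. Compound 3 `O=c1n(Cc2nc3ccccc3n2CCCC2(O)CC2)c2cnccc2n1C1CC1` carries the change (1-hydroxycyclopropyl in place of 2-hydroxyethyl on a saturated chain carbon, three bonds along the chain from an aromatic nitrogen). Within the data shown here, no measured step covers this exchange of one hydroxy-bearing group for another; the single measured step concerns a different group and gives no direction for it. In this assay compound 3 is therefore expected near the limit as well, a step of an at least 1.1-fold lower number from compound 2 to compound 3 (0.05 log units; that floor lies within the scatter). The estimate for compound 3 is 200000 nM, range 80000 nM to 500000 nM.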

Compound 3, half-maximal cytotoxic concentration: 131000 nM
Beside the measured number, compound 3's estimate is 1.5-fold (0.18 log units) above it; the measured number falls inside the stated range.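

With 1-hydroxycyclopropyl on the chain, this assay now gives a true number for a hydroxy-bearing group in place of isopropylsulfonyl: a 2.7-fold higher number from compound 1 to compound 3 (0.43 log units; beyond the scatter). The exchange of 2-hydroxyethyl for 1-hydroxycyclopropyl reads as an at least 1.7-fold lower number from compound 2 to compound 3 (0.24 log units; that floor lies within the scatter), so the gap between these two groups remains unfixed. The value of compound 2 is a limit and not a number: the limit of > 229000 nM in this assay, at which 1 of the 3 values shown sits.

On these data alone, how an amine or a carboxylic acid in this place would read in this assay stays open. The same holds for a hydroxy group carried on a longer chain.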